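The source may hold more compounds than are shown below. What is called first, only, known or untested is meant among the compounds shown, and "the series" means these compounds.

Working notes on the series. Compound 1 `Nc1nc(N)c(CCCN(Cc2ccc(NC(CCC(=O)O)C(=O)O)cc2)c2cc(F)c(F)cc2[N+](=O)[O-])c(O)n1`, compound 2 `Nc1nc(N)c(CCCN(Cc2ccc(NC(CCC(=O)O)C(=O)O)cc2)c2ccc([N+](=O)[O-])c(F)c2F)c(O)n1` and compound 3 `Nc1nc(N)c(CCCN(Cc2ccc(NC(CCC(=O)O)C(=O)O)cc2)c2cc(F)cc(F)c2[N+](=O)[O-])c(O)n1` share one core and differ only in the difluoronitrophenyl group on the amine nitrogen. In a functional assay on CCRF-CEM cells (Homo sapiens) for cytotoxicity, in the absence of a further agent (on this read-out lower numbers stand for stronger inhibition and higher numbers for weaker inhibition), compound 2 gives > 100000 nM, which is a limit of the assay and not a number. Compound 1 gives > 100000 nM, also a limit. Compound 3 gives > 100000 nM, again a limit. The whole set so far therefore stands at the limit of > 100000 nM in this assay, at which 3 of the 3 values shown sit.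

Compound 4 `Nc1nc(N)c(CCCN(Cc2ccc(NC(CCC(=O)O)C(=O)O)cc2)c2ccc([N+](=O)[O-])c(F)c2[N+](=O)[O-])c(O)n1` departs from compound 2 by nitro in place of fluoro on an aromatic carbon.

The nearest measured steps are a step that the two limits leave unreadable from compound 1 to compound 2, a step that the two limits leave unreadable from compound 2 to compound 3 and a step that the two limits leave unreadable from compound 1 to compound 3. None of them exchanges fluoro for nitro, and none has a readable size, so they set no scale for this change. No step beyond the scatter is therefore expected in this assay, and a further reading at the limit is the likely outcome. That expectation rests on compound 2, whose reading is the limit > 100000 nM. The estimated a number no higher from compound 2 to compound 4 (the limit leaves the size open) is no larger than the scatter. The estimate for compound 4 is 100000 nM, with an expected range of 40000 nM to 200000 nM.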

Compound 4, half-maximal inhibitory concentration: 48000 nM
Estimate against measurement, compound 4: 2.1-fold (0.32 log units) above; the measured number falls inside the stated range.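

In this assay, among the compounds shown here, nitro in place of fluoro on an aromatic carbon, at a place ortho to a fluoro group and meta to a nitro group, gives an at least 2.0-fold lower number from compound 2 to compound 4 (0.31 log units; beyond the scatter), the only readable step so far and one beyond the scatter. For the compounds shown here, this shows that the read-out can respond to a change at this position, with compound 4 at 48000 nM as the one value that is a number. Compound 2 stands at a limit, and the step has no upper bound. Compound 1, compound 2 and compound 3 each stand at a limit of the assay and not at a number, and the steps among them cannot be read: the limit of > 100000 nM in this assay, at which 3 of the 4 values shown sit.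

Whether the change depends on nitro itself stays open, since no other group on this carbon, such as an amine, a nitrile or a chloro group, appears among the compounds shown. Also open, as far as these compounds go, is whether nitro in place of fluoro would have a similar effect at another carbon of the ring or on the 4,5-difluoro-2-nitrophenyl or 3,5-difluoro-2-nitrophenyl groups.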